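This account rests on a few compounds, and the source may have more. Where it says the series, first, only, none or still open, it means among the compounds named here.

Measured compounds:
- compound 1 `CN1CCN(Cc2nnc(-c3cc(S(N)(=O)=O)c(SCc4ccccc4)cc3Cl)o2)CC1` gives 75000 nM in a functional assay on HeLa cells (Homo sapiens) for cytotoxicity, read by MTT assay, with a stated time of 72 h; a lower number here means a stronger inhibitor, a higher number a weaker inhibitor
- compound 2 `CC(C)(O)c1cn(Cc2nnc(-c3cc(S(N)(=O)=O)c(SCc4ccccc4)cc3Cl)o2)nn1` gives 68000 nM in this assay
- compound 3 `NCc1nnc(-c2cc(S(N)(=O)=O)c(SCc3ccccc3)cc2Cl)o1` gives 490000 nM in this assay

Compound 3 stands at the highest number of the three, so it is the weakest of the measured compounds. Compared with compound 1 the step is a 6.5-fold higher number from compound 1 to compound 3 (0.82 log units; beyond the scatter), and compared with compound 2 it is a 7.2-fold higher number from compound 2 to compound 3 (0.86 log units; beyond the scatter); compound 1 and compound 2 themselves are separated by only a 1.1-fold lower number from compound 1 to compound 2 (0.04 log units; within the scatter).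

Compound 4 `NS(=O)(=O)c1cc(-c2nnc(/C=C/c3ccccc3)o2)c(Cl)cc1SCc1ccccc1` differs from compound 3 in one place: 2-phenylethenyl in place of aminomethyl on an aromatic carbon. Among the measured compounds shown here, no measured step swaps the whole aminomethyl for such a group, so the closest guide is the two steps above, in which a plain amino group on that chain carbon gave the higher number while a larger attachment gave the lower. On that basis a modestly lower number is expected in this assay for compound 4, a step of about a 5.4-fold lower number from compound 3 to compound 4 (0.74 log units; beyond the scatter). Compound 4 is thus estimated at 90000 nM, with a range from 30000 nM to 300000 nM.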

Compound 4, half-maximal inhibitory concentration: 14000 nM
Estimate against measurement, compound 4: 6.4-fold (0.81 log units) above; the whole stated range lies above it.
By their numbers in this assay, from the lowest: compound 4; then compounds 2 and 1 (each within the scatter of the next); then compound 3.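

Earlier compounds changed only what sits on a saturated chain carbon at this spot on the ring. Compound 4 replaces that whole arrangement with 2-phenylethenyl, which brings one six-membered aromatic ring of carbon only and 1 double bond outside aromatic rings, and in this assay this gives a 35-fold lower number from compound 3 to compound 4 (1.54 log units; beyond the scatter). The lower number holds against the larger attachments too, with a 4.9-fold lower number from compound 2 to compound 4 (0.69 log units; beyond the scatter) and a 5.4-fold lower number from compound 1 to compound 4 (0.73 log units; beyond the scatter), so compound 4 has the lowest number of the four, although nothing measured here explains the result.

Going by these compounds, the ring and the double bond enter together, so their separate contributions remain open. A 2-phenylethyl chain, with the double bond saturated, or a phenyl group placed directly on the ring would help to separate them, and a methoxy group or fluorine on the new phenyl ring would test how far the gain extends.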